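Working notes: bromo in place of chloro on compound 3

The source may report more compounds than this note shows. Statements on the series, on what has been measured and on what is new or still open speak of the compounds shown alone.

Measured in a functional assay on HT-1080 cells (Homo sapiens) for cytotoxicity, read by MTT assay, with a stated time of 72 h; a higher number here means a weaker inhibitor, a lower number a stronger inhibitor:
- compound 1 `COc1cccc(/C=C2\CCC/C(=C\c3ccc(O)cc3)C2=O)c1OC`: > 20000 nM, a limit
- compound 2 `COc1cccc(/C=C2\CCC/C(=C\c3ccc(Cl)cc3Cl)C2=O)c1OC`: > 20000 nM, a limit
- compound 3 `COc1ccc(/C=C2\CCC/C(=C\c3cccc(Cl)c3)C2=O)cc1OC`: 4900 nM

Among the compounds with values here, compound 3 holds the only true number in this assay, at 4900 nM. The other two compounds give only (the limit of > 20000 nM in this assay, at which 2 of the 3 values shown sit). Compound 4 `COc1ccc(/C=C2\CCC/C(=C\c3cccc(Br)c3)C2=O)cc1OC` is the next structure, with this difference from compound 3: bromo in place of chloro on an aromatic carbon. Within the data shown here, the one measured step is a step that the two limits leave unreadable from compound 1 to compound 2, and it offers no size to carry over to this exchange of one halogen for another. No step beyond the usual scatter is therefore expected, in either direction, and the expectation rests on compound 3 at 4900 nM. The expected step is a 1.1-fold lower number from compound 3 to compound 4 (0.04 log units; within the scatter). The estimate for compound 4 is 4500 nM, with an expected range of 2000 nM to 10000 nM.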

Compound 4, half-maximal inhibitory concentration: 5200 nM
Beside the measured number, compound 4's estimate is 1.2-fold (0.06 log units) below it, within the range that was stated.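

In this assay, bromo in place of chloro on this aromatic carbon, meta to a large group, gives a 1.1-fold higher number from compound 3 to compound 4 (0.03 log units; within the scatter). Within the data shown here, this is the first readable step, and 3-chlorophenyl and 3-bromophenyl are not distinguished by it. Compound 4 also adds a second true number beside compound 3.

As far as these compounds go, whether a non-halogen group at this position, such as an amine or a carboxylic acid, would give a readable step remains open. The step from compound 1 to compound 2 cannot be read, as both values are limits: the limit of > 20000 nM in this assay, at which 2 of the 4 values shown sit.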